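Methyl for Hydrogen on the Phenyl of Compound 3

A few compounds are considered here, and "the series" means these few. Any claim that something is new, unique, unknown or untested is made for them only; others in the source may bear on it.

Compound 1 `CC(C)(C)c1cc(NC(=O)Nc2ccc(F)cc2)n(-c2ccccc2)n1` gives 7.4 degrees C in an assay on isolated protein for inhibition of STE20-like serine/threonine-protein kinase (Homo sapiens), read by thermal shift assay, tested at 10 uM; on this read-out lower numbers stand for weaker stabilisation of the target and higher numbers for stronger stabilisation of the target against heat.
Compound 2 `CC(C)(C)c1cc(NC(=O)Nc2ccc(F)c(F)c2)n(-c2ccccc2)n1` gives 5.5 degrees C in this assay.
Compound 3 `CC(C)(C)c1cc(NC(=O)Nc2ccccc2)n(-c2ccccc2)n1` gives 7.7 degrees C in this assay.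

Compound 3 holds the highest of the three numbers. Compound 1 sits within the scatter of it, as a number 0.30 degrees C higher from compound 1 to compound 3 (within the scatter) shows, while compound 2 lies furthest away, as a number 2.2 degrees C higher from compound 2 to compound 3 (beyond the scatter) shows. Among the measured compounds shown here, the only other measured step, a number 1.9 degrees C lower from compound 1 to compound 2 (beyond the scatter), also concerns fluoro on the phenyl.

Compound 4 `Cc1ccc(NC(=O)Nc2cc(C(C)(C)C)nn2-c2ccccc2)cc1` differs from compound 3 by methyl in place of hydrogen on an aromatic carbon. For the measured compounds named here, none of the measured steps involves a methyl; they bear on the change only in that a single substituent on this ring moved the number by at most a modest amount, and that the removal of one fluoro left the number within the scatter. Compound 4 is therefore expected to show no step beyond the scatter, a number 0.20 degrees C lower from compound 3 to compound 4 (within the scatter), in this assay. Compound 4 is estimated at 7.5 degrees C, with a range from 5.5 degrees C to 9 degrees C.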

Compound 4, shift of the target's melting temperature: 4.6 degrees C
The estimate for compound 4 lay 2.9 degrees C above the measured number; measured number outside the range, below it.
By their numbers in this assay, from the lowest: compounds 4 and 2 (each within the scatter of the next); then compounds 1 and 3 (each within the scatter of the next).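

In this assay this position proved sensitive to which group it carries: methyl in place of hydrogen gave a clear drop (a number 3.1 degrees C lower from compound 3 to compound 4 (beyond the scatter)), and methyl in place of fluoro gave one of similar size (a number 2.8 degrees C lower from compound 1 to compound 4 (beyond the scatter)), although hydrogen and fluoro had stayed within the scatter of each other. The 4-methylphenyl group instead ends up level with the 3,4-difluorophenyl group (a number 0.90 degrees C lower from compound 2 to compound 4 (within the scatter)). Nothing among the available data accounts for the effect of the methyl.

From the compounds shown here alone, it remains open whether the loss is particular to methyl or extends to other groups on this carbon, such as ethyl, methoxy, chloro or an amine. Going by these compounds, it is also open whether methyl on another carbon of this ring would give a similar number.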